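Trifluoromethyl on the cyclopropyl ring of compound 2

The source may hold more compounds than are shown below. What is called first, only, known or untested is meant among the compounds shown, and "the series" means these compounds.

Compound 1 `CC(C)Cn1nc(-c2cccs2)c(O)c(C2=NS(=O)(=O)c3cc(NS(C)(=O)=O)ccc3N2)c1=O` and compound 2 `CS(=O)(=O)Nc1ccc2c(c1)S(=O)(=O)N=C(c1c(O)c(-c3cccs3)nn(CC3CC3)c1=O)N2` were tested in an in vitro ADME assay on microsomes from liver (Homo sapiens) for metabolic stability, tested at 5 uM (a higher number here means that the compound lasts longer, a lower number that the compound disappears faster), and share a core. Compound 1 gives > 1 h as a limit of the assay. Compound 2 gives > 1 h as a limit too. All that is measured is the limit of > 1 h in this assay, at which 2 of the 2 values shown sit, and so a step that the two limits leave unreadable from compound 1 to compound 2 offers no size to carry forward. Compound 3 `CS(=O)(=O)Nc1ccc2c(c1)S(=O)(=O)N=C(c1c(O)c(-c3cccs3)nn(CC3(C(F)(F)F)CC3)c1=O)N2` differs from compound 2 by trifluoromethyl in place of hydrogen on a saturated ring carbon with trifluoromethyl in place of hydrogen on a saturated ring carbon. No direction can therefore be read from the data, and the expected step is a step that the limit leaves unreadable from compound 2 to compound 3 with wide uncertainty. Compound 3 is estimated at 1.5 h within a range of 0.8 h to 3 h in this assay as the likely reading.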

Compound 3, half-life: > 1 h
Compound 3: no number, only a limit; the forecaster's own chance of this, stated with the estimate: 75%; the middle value is on the limit's open side.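

No new step can be read among compound 1, compound 2 and compound 3, because all three give only a limit: the limit of > 1 h in this assay, at which 3 of the 3 values shown sit.

The compounds shown leave open how long each actually lasts in this assay, and whether the trifluoromethyl group makes any difference.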